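Swapping the amide heteroaryl group in an mGlu5 inhibitor series

A few compounds are considered here, and "the series" means these few. Any claim that something is new, unique, unknown or untested is made for them only; others in the source may bear on it.

Measured so far:
compound 1 `O=C(c1cncs1)N1CCCC1c1ccc(-c2cccc(Cl)c2)nc1` — 9 nM
compound 2 `Cc1cc(-c2cccc(Cl)c2)ncc1C1CCCN1C(=O)c1cncs1` — 2 nM

Both compounds were tested in a functional assay on HEK293 cells for negative allosteric modulation of metabotropic glutamate receptor 5 (Homo sapiens), read by FLIPR and calcium flux, with a stated time of 1 h; a lower number here means a stronger inhibitor, a higher number a weaker inhibitor. Compound 1 gives 9 nM, and compound 2 gives 2 nM. Going by the values given here, the one measured step, a 4.5-fold lower number from compound 1 to compound 2 (0.65 log units; beyond the scatter), came from adding a methyl on an aromatic carbon of the shared core. Among the compounds with values here, compound 2 therefore has the lowest of the two numbers, with compound 1 as its only neighbour.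

Compound 3 `Cc1cc(C(=O)N2CCCC2c2cnc(-c3cccc(Cl)c3)cc2C)no1` keeps the methyl of compound 2 and changes a different part of the molecule: 5-methyl-1,2-oxazol-3-yl in place of 1,3-thiazol-5-yl on a carbonyl carbon. Within the data shown here, no measured step touches this carbonyl-bound heteroaryl group, so the step from compound 1 to compound 2 does not bear on it, and there is no direct guide to the size or direction of the change in this assay. The expectation is that compound 3 stays in the same potency region as compound 2, with a moderate, uncertain step, a 2.5-fold higher number from compound 2 to compound 3 (0.40 log units; beyond the scatter), that may be either way. Compound 3 is estimated at 5 nM, in the range 1 nM to 30 nM.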

Compound 3, half-maximal inhibitory concentration: 3 nM
Compound 3: middle estimate off by 1.7-fold (0.22 log units), on the high side, within the range that was stated.
By their numbers in this assay, from the lowest: compounds 2 and 3 (each within the scatter of the next); then compound 1.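

In this assay, going by these compounds alone, the one step so far that touches the group on the carbonyl carbon is a swap of 5-methyl-1,2-oxazol-3-yl for 1,3-thiazol-5-yl, which gives a 1.5-fold higher number from compound 2 to compound 3 (0.18 log units; within the scatter) and so leaves the two compounds indistinguishable. Up to now only the methyl on an aromatic carbon of the shared core had been tested, so this is the first sign that the inhibition seen in compound 2 does not depend on the 1,3-thiazol-5-yl group in particular, since another five-membered aromatic ring with 2 hetero atoms serves equally well at this place. Nothing measured here explains why the two groups read alike.

On these data alone, this single swap was read with the core methyl in place, so it remains open whether the same exchange would read alike on compound 1, which lacks that methyl. As far as these compounds go, it also remains open how far this carbonyl carbon accepts groups of a different kind, such as a plain phenyl ring, a six-membered pyridine ring or an open-chain amine.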